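A few compounds are considered here, and "the series" means these few. Any claim that something is new, unique, unknown or untested is made for them only; others in the source may bear on it.

Compound 1, `O=C(CN1CCN(C2CCCCC2)CC1)Nc1nc2c(s1)CCCC2`: in an assay on isolated protein for inhibition of long-chain fatty acid transport protein 1 (Homo sapiens), read by scintillation counting, with a stated time of 20 min (a higher number here means a weaker inhibitor, a lower number a stronger inhibitor), compound 1 gives > 1000 nM, which is a limit of the assay and not a number.
Compound 2, `O=C(CN1CCN(c2cccc(F)c2)CC1)Nc1nc2c(s1)CCCC2`: in this assay compound 2 gives > 1000 nM, again a limit of the assay.
Compound 3, `O=C(CN1CCN(c2ccc(F)cc2)CC1)Nc1nc2c(o1)CCCC2`: in this assay compound 3 gives 180 nM.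

Compound 2 therefore stands at the weak end of what was measured, at the limit of > 1000 nM in this assay, at which 2 of the 3 values shown sit. Going by the values given here, the single measured step that touches it, a step that the two limits leave unreadable from compound 1 to compound 2, runs between two limits and so its size cannot be read. Compound 4, `O=C(CN1CCN(c2ccncc2)CC1)Nc1nc2c(s1)CCCC2`, differs from compound 2 in one place: pyridin-4-yl in place of 3-fluorophenyl on an amine nitrogen in a ring. Among the compounds with values here, no measured step covers a swap of this kind; compound 3 carries a 4-fluorophenyl on a different core, so its value shows only that a number within range can be reached. With compound 2 itself a limit, any step from it is unreadable in size, and compound 4 is expected to sit near the same limit, with a chance of a readable number. Compound 4 is estimated at 2000 nM, ranging from 400 nM to 10000 nM, which would mean an expected step that the limit leaves unreadable from compound 2 to compound 4.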

Compound 4, half-maximal inhibitory concentration: > 1000 nM
Compound 4 gave a limit, no number (the forecaster's own chance of this, stated with the estimate: 60%); the middle value is on the limit's open side.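

Going by these compounds alone, compound 1, compound 2 and compound 4 all sit at a limit of the assay and not at a number, so no step among them can be read: the limit of > 1000 nM in this assay, at which 3 of the 4 values shown sit. The compounds shown leave open whether cyclohexyl, 3-fluorophenyl and pyridin-4-yl differ at all in this assay on the shared core.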